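A few compounds are considered here, and "the series" means these few. Any claim that something is new, unique, unknown or untested is made for them only; others in the source may bear on it.

Of the compounds shown here, three have been tested in a functional assay on the whole organism (strain Kunming) with Mus musculus as the target; on this read-out higher numbers stand for an effect only at larger amounts of compound and lower numbers for an effect already at smaller amounts. Compound 1 `O=C1CC(c2ccccc2Cl)n2ncnc2N1` gives 25.5 mg/kg in this assay, compound 2 `O=C1CC(c2cccc(C(F)(F)F)c2)n2ncnc2N1` gives 54.8 mg/kg, and compound 3 `O=C1CC(c2ccccc2)n2nccc2N1` gives 47.3 mg/kg. Compound 3 stands second highest of the three numbers, yet its gap to compound 2 and its gap to compound 1 both fall within the usual scatter, so no real separation among them can be claimed. Compound 4 `O=C1CC(c2ccccc2Cl)n2nccc2N1` has not yet been measured; it differs from compound 3 by chloro in place of hydrogen on an aromatic carbon. Among the measured compounds shown here, no comparable step between measured compounds is available. Compound 4 is expected to show a step of a 1.5-fold lower number from compound 3 to compound 4 (0.17 log units; within the scatter), a change likely within the scatter, since compound 1 carries the same chloro group and gives 25.5 mg/kg. The estimate for compound 4 is 32 mg/kg, with a range from 15 mg/kg to 65 mg/kg.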

Compound 4, dose for half-maximal effect: 63.4 mg/kg
Estimate against measurement, compound 4: 2.0-fold (0.30 log units) below; low and high end bracket the measured number.
By their numbers in this assay, from the lowest: compounds 1, 3, 2 and 4 (each within the scatter of the next, the first and the last beyond it).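

In this assay the first pair differing in one place gives a 1.3-fold higher number from compound 3 to compound 4 (0.13 log units; within the scatter) for chloro in place of hydrogen on an aromatic carbon, ortho to a large group. At this position on this core, then, compound 3 and compound 4 cannot be told apart, so chloro here gives no measurable separation from hydrogen. Nothing on hand offers an explanation for this result. Still open, as far as these compounds go, is whether an amine or a carboxylic acid at this position would separate from hydrogen beyond the scatter. From the compounds shown here alone, whether chloro would behave alike elsewhere on the six-membered ring also remains unknown.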